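The compounds below may be only part of what the source reports. "The series", "measured", "known", "first", "only" and "open" are said of these compounds alone.

Compound 1 `CC(CSc1nnc(-c2ccncc2)s1)C(=O)NCc1ccccc1Cl` gives > 50000 nM in an ADME assay on HepG2 cells (Homo sapiens) for cytotoxicity, with a stated time of 3 days (a higher number here means that more compound is tolerated, a lower number that less compound is tolerated), which is a limit of the assay and not a number.
Compound 2 `CC(CSc1nnc(-c2ccncc2)s1)C(=O)Nc1ccc(Cl)cc1Cl` gives > 50000 nM in this assay, again a limit rather than a number.
Compound 3 `CC(CSc1nnc(-c2ccncc2)s1)C(=O)NCc1ccc(Cl)cc1` has no result in this assay: "not determined" (no result reported).

Compound 3 therefore has no place on the numbers shown; both values that exist sit at a limit (the limit of > 50000 nM in this assay, at which 2 of the 3 values shown sit). The step from compound 3 to compound 4 `CC(CSc1nnc(-c2ccncc2)s1)C(=O)Nc1ccccc1` is phenyl in place of 4-chlorobenzyl on an amide-type nitrogen. For the measured compounds named here, the only measured step, a step that the two limits leave unreadable from compound 1 to compound 2, also changes the group on the amide-type nitrogen, but its size cannot be read since both ends are limits. Going by the values given here, no measured step bears on the change from compound 3 to compound 4, so neither its direction nor its size in this assay can be read. Given that every value shown sits at the limit (the limit of > 50000 nM in this assay, at which 2 of the 3 values shown sit), compound 4 is expected to give 50000 nM, within 20000 nM to 100000 nM, most probably again reported only as a limit.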

Compound 4, half-maximal cytotoxic concentration: > 50000 nM
Compound 4 gave a limit, no number; the forecaster's own chance of this, stated with the estimate: 80%; the middle value sits exactly at the limit.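

For the compounds shown here, no step among compound 1, compound 2 and compound 4 can be read, since each result is only a limit: the limit of > 50000 nM in this assay, at which 3 of the 4 values shown sit. As far as these compounds go, whether the group on the amide-type nitrogen changes anything in this assay stays open.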